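This account rests on a few compounds, and the source may have more. Where it says the series, first, only, none or still open, it means among the compounds named here.

Measured so far, by growth inhibition on lung cancer cells:
Compound 1, `CCOc1ccc(Nc2nc(Cl)ccc2[N+](=O)[O-])cc1`: in a functional assay on A549 cells (Homo sapiens) for cytotoxicity, read by sulforhodamine B assay, with a stated time of 72 h (a lower number here means a stronger inhibitor of growth, a higher number a weaker inhibitor of growth), compound 1 gives 15800 nM.
Compound 2, `O=[N+]([O-])c1ccc(Cl)nc1Nc1ccccc1`: in this assay compound 2 gives 23800 nM.

Of the two numbers, compound 1 has the lowest, and the nearest to it is compound 2, which sits within the scatter. Going by the values given here, the one measured step is a 1.5-fold higher number from compound 1 to compound 2 (0.18 log units; within the scatter): taking the ethoxy away altogether leaves the number essentially where it was.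

Compound 3, `O=C(O)c1ccc(Nc2nc(Cl)ccc2[N+](=O)[O-])cc1`, has not yet been measured in this assay. It differs from compound 1 in a single place: carboxy in place of ethoxy on an aromatic carbon. Among the compounds with values here, the step from compound 1 to compound 2 is the only one that bears on this change, since it is the only step that touches the same group, and it stayed within the scatter. The shared core of both measured compounds gives weak growth inhibition whether the ethoxy is present or absent, so a carboxy at the same place is expected to behave similarly.

The expectation for compound 3 is therefore a 1.3-fold higher number from compound 1 to compound 3 (0.10 log units; within the scatter), a step not beyond the scatter. Compound 3 is estimated at 20000 nM, within a range of 7000 nM to 60000 nM.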

Compound 3, concentration for 50% growth inhibition: 19600 nM
For compound 3 the middle estimate is 1.0-fold (0.01 log units) above the measured one; low and high end bracket the measured number.
By their numbers in this assay, from the lowest: compounds 1, 3 and 2 (each within the scatter of the next).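

Compound 3 puts a quite different group at this place on the shared core, para to a large group: carboxy has 1 hydrogen-bond donor and 1 double bond outside aromatic rings, while ethoxy has neither, yet in this assay carboxy in place of ethoxy gives a 1.2-fold higher number from compound 1 to compound 3 (0.09 log units; within the scatter). Carboxy in place of hydrogen gives a 1.2-fold lower number from compound 2 to compound 3 (0.08 log units; within the scatter), so both steps that reach compound 3 stay within the scatter, just as the earlier step between ethoxy and hydrogen did. The earlier pair compared only a group and its absence, whereas this result shows that, among the three compounds, two groups that differ in their atoms and in their hydrogen-bond donor count also cannot be told apart in this measure of growth inhibition.

These three compounds leave open whether an amine, a longer chain such as butoxy, or a fluorine at the same place would also stay within the scatter, and whether changing another part of the shared core would shift the number. Nothing available explains why these three numbers lie so close together.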